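Swapping oxan-4-yl for oxolan-2-yl in a sulfonamide series

The source may hold more compounds than are shown below. What is called first, only, known or untested is meant among the compounds shown, and "the series" means these compounds.

compound 1 `CC1(C)C[C@H](CN([C@H](CCC(F)(F)F)C(N)=O)S(=O)(=O)c2ccc(Cl)cc2)O1`: 3.8
compound 2 `CC1(C)CO[C@H]1CN([C@H](CCC(F)(F)F)C(N)=O)S(=O)(=O)c1ccc(Cl)cc1`: 3.8
compound 3 `NC(=O)[C@@H](CCC(F)(F)F)N(CC1CCOCC1)S(=O)(=O)c1ccc(Cl)cc1`: 3.5

In a physicochemical assay for lipophilicity, read by HPLC, measured as octanol-water partition, at pH 7.4 (a lower number here means a more polar compound, a higher number a more lipophilic compound), compound 3 gives 3.5. That places it within the scatter of both other compounds, so the three cannot be told apart on these numbers.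

The next structure, compound 4 `NC(=O)[C@@H](CCC(F)(F)F)N(C[C@@H]1CCCO1)S(=O)(=O)c1ccc(Cl)cc1`, has not been measured. It carries oxolan-2-yl in place of oxan-4-yl on a saturated chain carbon bound to a sulfonamide nitrogen. Cut one bond further out, the same difference reads (oxan-4-yl)methyl to (oxolan-2-yl)methyl.

Three measured steps changed the group at this same place. Oxan-4-yl in place of the two dimethyloxetanyl groups gave a number 0.30 log units lower from compound 1 to compound 3 (within the scatter) and a number 0.30 log units lower from compound 2 to compound 3 (within the scatter). 3,3-Dimethyloxetan-2-yl in place of 4,4-dimethyloxetan-2-yl gave no change at the digits printed from compound 1 to compound 2 (within the scatter). None of these steps left the scatter, although none of them involves oxolan-2-yl, so the evidence is indirect. On that basis, no change beyond the scatter is expected in this assay, and the data favour no clear direction.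

The expected size is a number 0.10 log units lower from compound 3 to compound 4 (within the scatter). For compound 4 the estimated value is 3.4, with an expected range from 3 to 3.8.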

Compound 4, distribution coefficient: 3.5
Beside the measured number, compound 4's estimate is 0.10 log units below it, and the stated range covers the measured number.
By their numbers in this assay, from the lowest: compounds 3, 4, 1 and 2 (each within the scatter of the next).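

In this assay, replacing oxan-4-yl with oxolan-2-yl gave no change at the digits printed from compound 3 to compound 4 (within the scatter) even though the ring went from six-membered to five-membered, from 6 heavy atoms to 5, and gained a defined stereocentre. Oxolan-2-yl also gave a number 0.30 log units lower from compound 2 to compound 4 (within the scatter) and a number 0.30 log units lower from compound 1 to compound 4 (within the scatter), so this place on a saturated chain carbon bound to a sulfonamide nitrogen has now held four different oxygen-containing rings, and all four compounds remain within the scatter of one another. No separate evidence bears on this result.

All four groups at this place are non-aromatic rings holding an oxygen atom, so the compounds shown leave open whether a different kind of group there, such as an amine like piperidin-4-yl or a carboxylic acid, would give a number beyond the scatter. They also leave open how the mirror-image form of the oxolan-2-yl group, with its stereocentre reversed, would read in this assay.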